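Fluoro substitution on the shared core of compound 2

The source may report more compounds than this note shows. Statements on the series, on what has been measured and on what is new or still open speak of the compounds shown alone.

Three compounds of the series carry numbers in an assay on a protein complex for inhibition of ubiquitin carboxyl-terminal hydrolase 1/WD repeat-containing protein 48 (Homo sapiens), read by fluorescence; on this read-out higher numbers stand for weaker inhibition and lower numbers for stronger inhibition. Compound 1 `N#Cc1ccc(CNc2nc(-c3ccccc3C(F)(F)F)nc3ccccc23)cc1` gives 5700 nM. Compound 2 `CC(C)c1ccccc1-c1nccc(NCc2ccc(-c3cccnc3)cc2)n1` gives 150 nM, the lowest of the three numbers, and compound 3 `Cc1cc(NCc2ccc(-c3cccnc3)cc2)nc(-c2ccccc2C(C)C)n1` gives 210 nM. Compound 2 stands nearest to compound 3, within the scatter, and furthest from compound 1, a gap beyond the scatter. Among the compounds with values here, the single one-point step measured so far, a 1.4-fold higher number from compound 2 to compound 3 (0.15 log units; within the scatter), lies within the scatter.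

Compound 4 `CC(C)c1ccccc1-c1ncc(F)c(NCc2ccc(-c3cccnc3)cc2)n1` is not yet measured. It differs from compound 2 by fluoro in place of hydrogen on an aromatic carbon, on an aromatic carbon of the six-membered aromatic ring with two nitrogens, ortho to a large group, two atoms from the ring nitrogen and para to the 2-isopropylphenyl group. Within the data shown here, the only measured step that bears on this change is the methyl for hydrogen exchange on the same ring, a 1.4-fold higher number from compound 2 to compound 3 (0.15 log units; within the scatter), which stayed within the scatter, and fluoro is likewise a single heavy atom with no donors or acceptors. No step beyond the scatter is therefore expected in this assay in either direction. Compound 4 is estimated at 160 nM, with a range from 70 nM to 400 nM, meaning an expected step of a 1.1-fold higher number from compound 2 to compound 4 (0.03 log units; within the scatter).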

Compound 4, half-maximal inhibitory concentration: 110 nM
Estimate against measurement, compound 4: 1.5-fold (0.16 log units) above; the measured number falls inside the stated range.
By their numbers in this assay, from the lowest: compounds 4, 2 and 3 (each within the scatter of the next); then compound 1.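

Fluoro in place of hydrogen on this aromatic carbon, para to a 2-isopropylphenyl group, gives a 1.4-fold lower number from compound 2 to compound 4 (0.13 log units; within the scatter) in this assay, so this position now has a measured step of its own, and a fluoro group here leaves the number within the scatter of compound 2. The earlier step, a 1.4-fold higher number from compound 2 to compound 3 (0.15 log units; within the scatter), concerned methyl on a different aromatic carbon of the ring, so it could not speak for this position directly. No evidence at hand bears on why this step has the size it has.

Open, as far as these compounds go, is whether another group on this carbon, such as an amine, a methoxy group or a carboxylic acid, would move the number beyond the scatter. Also open, from the compounds shown here alone, is whether fluoro here would give a similar step with a trifluoromethyl group in place of the isopropyl group.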